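The source may report more compounds than this note shows. Statements on the series, on what has been measured and on what is new or still open speak of the compounds shown alone.

Of the compounds shown here, two built on a shared core have so far been tested in a functional assay on MCF7 cells (Homo sapiens) for antiproliferative activity, read by sulforhodamine B assay, with a stated time of 48 h, tested at 50 uM; on this read-out lower numbers stand for less inhibition and higher numbers for more inhibition at the one concentration tested (going by the name of the read-out). Compound 1 `COc1cccc(C(=O)Oc2cc3c(cc2C)[C@@H](C(C)C)CC=C3C)c1` carries a methoxy group on an aromatic carbon, and in this assay compound 1 gives 11.9%. For the measured compounds named here, compound 2 `CC1=CC[C@H](C(C)C)c2cc(C)c(OC(=O)c3cccc(Cl)c3)cc21` has chloro in place of that methoxy, and compound 2 gives 40.4%, the higher of the two numbers available, with the single measured step of a number 28.5 percentage points higher from compound 1 to compound 2 (beyond the scatter) lying beyond the scatter.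

Compound 3 `CC1=CC[C@H](C(C)C)c2cc(C)c(OC(=O)c3cccc([N+](=O)[O-])c3)cc21` has not yet been measured. It differs from compound 2 by nitro in place of chloro on an aromatic carbon. Going by the values given here, no measured step involves a nitro group, so the only guide is that one earlier swap at the same aromatic carbon, a number 28.5 percentage points higher from compound 1 to compound 2 (beyond the scatter), shifted the read-out by a modest amount; a second swap there may move the number again, but its direction cannot be read from a single step. Taking the value of compound 2 as the anchor and allowing room either way, compound 3 is expected to give about 40%, between 15% and 65%. The step of a number 0.4 percentage points lower from compound 2 to compound 3 (within the scatter) that this estimate implies is expected to stay within the scatter.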

Compound 3, a percentage reported as inhibition, at one concentration (the size of the read-out at that concentration, not a potency): 29.3%
For compound 3 the middle estimate is 10.7 percentage points above the measured one, within the range that was stated.
By their numbers in this assay, from the lowest: compound 1; then compound 3; then compound 2.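

At this aromatic carbon, the change from 3-chlorophenyl to 3-nitrophenyl in this assay gives a number 11.1 percentage points lower from compound 2 to compound 3 (beyond the scatter), so the read-out responds to a second swap at this place, and this time it falls, whereas the earlier swap of methoxy for chloro gave a number 28.5 percentage points higher from compound 1 to compound 2 (beyond the scatter). Nitro also differs from methoxy, with a number 17.4 percentage points higher from compound 1 to compound 3 (beyond the scatter), which means that the three groups tried here stand apart from one another beyond the scatter: chloro gives the highest number, nitro the middle one and methoxy the lowest, all on the shared core. Nothing available accounts for this order, so the numbers describe what happens at this position without saying why it happens.

The compounds shown leave open whether an amine, a carboxylic acid or a longer chain at this same carbon would fall within this range or outside it, and whether chloro would keep its lead over such groups. They also leave open whether the same order would hold with these groups on another carbon of the ring, or at other concentrations than the single one tested.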